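Pyridinone series: sulfonyl substituent variation toward compound 3

The source may report more compounds than this note shows. Statements on the series, on what has been measured and on what is new or still open speak of the compounds shown alone.

Measured compounds:
- compound 1, `CCCCc1ccc(CNC(=O)OC(C)(C)C)c(=O)n1Cc1ccc(-c2ccccc2-c2nn[nH]n2)cc1`, 68.9%
- compound 2, `CCCCc1ccc(CN(Cc2ccccc2)S(=O)(=O)c2ccccc2)c(=O)n1Cc1ccc(-c2ccccc2-c2nn[nH]n2)cc1`, 75.7%

Both compounds were tested in a functional assay on the whole organism (artery) for inhibition, with Rattus norvegicus as the target, at a dose of 3 mg/kg by the intraduodenal route; a lower number here means less inhibition, a higher number more inhibition at the dose given (going by the name of the read-out). Compound 1 gives 68.9% in this assay, and compound 2 gives 75.7%. The two numbers lie within the usual scatter of each other, so compound 2 cannot be said to stand apart from compound 1 on this read-out; it is simply the number with the larger figure of the two. Compound 3, `CCCCc1ccc(CN(Cc2ccccc2)S(C)(=O)=O)c(=O)n1Cc1ccc(-c2ccccc2-c2nn[nH]n2)cc1`, has not been measured. It differs from compound 2 in one place: methyl in place of phenyl on a sulfonyl sulfur. Within the data shown here, no step between two measured compounds is known for this kind of change, so nothing among the numbers points to a direction. The expectation is a step from compound 2 to compound 3 of a number 5.7 percentage points lower from compound 2 to compound 3 (within the scatter), that is, none beyond the scatter, with a slight lean toward the lower side. Compound 3 is therefore estimated at 70%, with a range from 55% to 82%.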

Compound 3, a percentage reported as inhibition, in the whole organism at one dose (the size of the read-out at that dose, not a potency): 41.2%
Beside the measured number, compound 3's estimate is 28.8 percentage points above it, outside the stated range (below it).
By their numbers in this assay, from the lowest: compound 3; then compounds 1 and 2 (each within the scatter of the next).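

In this assay, among these compounds, the sulfonyl sulfur proves to be a place where the read-out responds to the substituent: methyl in place of phenyl gives a number 34.5 percentage points lower from compound 2 to compound 3 (beyond the scatter), the first one-place change with a measured size. Benzyl(methylsulfonyl)amino in place of (tert-butoxycarbonyl)amino on a saturated chain carbon bound to an aromatic carbon gives a number 27.7 percentage points lower from compound 1 to compound 3 (beyond the scatter), so compound 3 falls clearly short of both earlier compounds, and the phenylsulfonyl to methylsulfonyl change is not a neutral swap in this series. No measurement is at hand that bears on what lies behind this step.

With only phenyl and methyl shown on the sulfur, it remains open whether an ethyl group, a longer alkyl chain, a benzyl group, a fluorophenyl group or a thienyl ring would give a number close to that of compound 2 or of compound 3. Going by these compounds, it is also open whether the step between these two sulfonyl groups would keep its size at other doses, as each number here comes from a single dose and is not a potency.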